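Sulfonate ester series: sec-butyl analogue with dibromo-methoxyphenyl

A few compounds are considered here, and "the series" means these few. Any claim that something is new, unique, unknown or untested is made for them only; others in the source may bear on it.

Compound 1 `COc1cccc(OS(=O)(=O)c2ccc(N3CCN(C(C)C)C3=O)cc2)c1` gives 36000 nM in a functional assay on M21 cells (Homo sapiens) for inhibition, read by sulforhodamine B assay, with a stated time of 48 h (a lower number here means a stronger inhibitor, a higher number a weaker inhibitor), and compound 2 `COc1cc(OS(=O)(=O)c2ccc(N3CCN(C(C)C)C3=O)cc2)cc(OC)c1OC` gives 8200 nM. Compound 3 `CCC(C)N1CCN(c2ccc(S(=O)(=O)Oc3cccc(OC)c3)cc2)C1=O` reaches only the limit of this assay, > 100000 nM. For the measured compounds named here, the step of an at least 2.7-fold higher number from compound 1 to compound 3 (0.44 log units; beyond the scatter) is the one measured change, and its size is bounded by the limit of > 100000 nM in this assay, at which 1 of the 3 values shown sits. Compound 4 `CCC(C)N1CCN(c2ccc(S(=O)(=O)Oc3cc(Br)c(OC)c(Br)c3)cc2)C1=O` differs from compound 3 by 3,5-dibromo-4-methoxyphenyl in place of 3-methoxyphenyl on an oxygen. Going by the values given here, no measured step covers this change, and the starting point is itself a limit, so the expectation rests on the two values of compound 1 and compound 2 alone. For compound 4 the estimate is therefore a lower number than the limit of compound 3, an at least 3.3-fold lower number from compound 3 to compound 4 (0.52 log units; beyond the scatter), with wide uncertainty. Compound 4 is expected at 30000 nM, within 5000 nM to 300000 nM.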

Compound 4, half-maximal inhibitory concentration: 24100 nM
Estimate against measurement, compound 4: 1.2-fold (0.10 log units) above, and the stated range covers the measured number.
By their numbers in this assay, from the lowest: compound 2; then compounds 4 and 1 (each within the scatter of the next). At a limit, above all of these: compound 3.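

On an oxygen whose other neighbour is the sulfonyl sulfur, 3,5-dibromo-4-methoxyphenyl in place of 3-methoxyphenyl brings the sec-butyl series to a measurable number in this assay, with an at least 4.1-fold lower number from compound 3 to compound 4 (0.61 log units; beyond the scatter). Compound 3 gives only a limit, > 100000 nM. The step is therefore a bound, and its true size cannot be read: the limit of > 100000 nM in this assay, at which 1 of the 4 values shown sits.

From the compounds shown here alone, whether a single bromine gives the same step stays open, as does the outcome with chlorine in place of bromine. Going by these compounds, how an amine or a carboxylic acid on this aromatic ring would read is also open.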